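The compounds below may be only part of what the source reports. "The series", "measured", "known", "first", "only" and "open" are said of these compounds alone.

Compound 1 `O=C(Nc1ccc(C(F)(F)F)cc1)NC1CCN(C(=O)C2=COCC2)CC1` carries a trifluoromethyl group on its aryl urea and a five-membered non-aromatic ring on the carbonyl carbon next to the ring nitrogen. In a physicochemical assay for solubility, read by mass spectrometry, in phosphate buffer, with a stated time of 24 h, at pH 7.4 (on this read-out lower numbers stand for lower solubility and higher numbers for higher solubility), compound 1 gives 2.3 ug/mL, the lowest of the three numbers measured. Compound 2 `CC(C)C(=O)N1CCC(NC(=O)Nc2ccc(C(F)(F)F)c(F)c2)CC1` gives 5.9 ug/mL, and compound 3 `O=C(Nc1ccc(OC(F)(F)F)cc1)NC1CCN(C(=O)C2CCOCC2)CC1` gives 91 ug/mL, both higher, with compound 3 the highest by a margin beyond the usual scatter.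

Compound 4 `Cc1ccoc1C(=O)N1CCC(NC(=O)Nc2ccc(C(F)(F)F)cc2)CC1` differs from compound 1 in one place: a group of 6 heavy atoms (5 carbon, 1 oxygen; one five-membered aromatic ring with 1 hetero atom) in place of a group of 5 heavy atoms (4 carbon, 1 oxygen; one five-membered non-aromatic ring with 1 hetero atom), on a carbonyl carbon. Since compound 1 sits at 2.3 ug/mL, the step from compound 1 to compound 4 in this assay is expected to be small, a 1.2-fold lower number from compound 1 to compound 4 (0.06 log units; within the scatter), downward if anything. Compound 4 is therefore estimated at 2 ug/mL, in the range 0.7 ug/mL to 6 ug/mL.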

Compound 4, solubility: 0.8 ug/mL
Estimate against measurement, compound 4: 2.5-fold (0.40 log units) above; low and high end bracket the measured number.
By their numbers in this assay, from the lowest: compound 4; then compound 1; then compound 2; then compound 3.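

On the carbonyl carbon, 3-methylfuran-2-yl in place of the five-membered non-aromatic ring gives a 2.9-fold lower number from compound 1 to compound 4 (0.46 log units; beyond the scatter) in this assay. Among the compounds shown here, this is the first comparison here that changes only one place, and it shows that the number responds to the group held there, even though the core stays the same. Nothing measured here bears on why the number moves.

On these data alone, the step changes the ring and adds the methyl together, so their separate shares remain open. Also open, as far as these compounds go, is what a plain furan-2-yl or a group carrying an amine would give on this carbonyl carbon.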